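From pyridin-3-yl to 5-bromopyridin-3-yl

The source may report more compounds than this note shows. Statements on the series, on what has been measured and on what is new or still open speak of the compounds shown alone.

In a functional assay on MDA-MB-231 cells (Homo sapiens) for cytotoxicity, read by MTT assay, with a stated time of 72 h (a higher number here means a weaker inhibitor, a lower number a stronger inhibitor), compound 1 `Nc1ccccc1NC(=O)c1ccc(NC(=S)NCc2cccc(F)c2)cc1` gives 74000 nM. Compound 2 `Nc1ccccc1NC(=O)c1ccc(NC(=S)NCc2cccnc2)cc1` has no number to stand on, and its result reads "not determined" (no result reported). Compound 3 `Nc1ccccc1NC(=O)c1ccc(NC(=S)NCc2cncc(Br)c2)cc1` differs from it by one change, bromo in place of hydrogen on an aromatic carbon, two atoms from the ring nitrogen: bromo in place of hydrogen on an aromatic carbon. Within the data shown here, no measured step guides the expectation, so the only anchor is compound 1 at 74000 nM. A modest shift towards a stronger inhibitor is expected in this assay, possibly none beyond the scatter. For compound 3 the expected value is 50000 nM, with an estimated range from 15000 nM to 150000 nM.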

Compound 3, half-maximal inhibitory concentration: 39000 nM
Estimate against measurement, compound 3: 1.3-fold (0.11 log units) above; the measured number falls inside the stated range.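

In this assay, 5-bromopyridin-3-yl in place of 3-fluorophenyl gives a 1.9-fold lower number from compound 1 to compound 3 (0.28 log units; within the scatter) and thus leaves the two groups indistinguishable at this place on the chain. Compound 2 has no number, so the step from hydrogen to bromo on the pyridine ring cannot be read. No measurement shown here bears on this result. The compounds shown leave open how chloro, methoxy, an amine or a nitrile would read on that same aromatic carbon, two atoms from the ring nitrogen.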